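Replacing the 2-methylphenyl of compound 2 with pyridin-3-yl

This account rests on a few compounds, and the source may have more. Where it says the series, first, only, none or still open, it means among the compounds named here.

Compound 1 `COc1cc2c(cc1OC)C(CC(=O)Nc1ccc(Cl)cc1)CC2`, compound 2 `COc1cc2c(cc1OC)C(CC(=O)Nc1ccccc1C)CC2` and compound 3 `COc1cc2c(cc1OC)C(CC(=O)Nc1ccc([N+](=O)[O-])cc1)CC2` share one core and differ only in the aryl group on the amide nitrogen. In a functional assay on the whole organism (strain Wistar) for inhibition, with Rattus norvegicus as the target, read by paw edema, with a stated time of 6 h, at a dose of 100 mg/kg (on this read-out higher numbers stand for more inhibition at the one dose given (going by the name of the read-out) and lower numbers for less inhibition), compound 1 gives 61.1%, compound 3 gives 37%, and compound 2 gives 25.9%, the lowest of the three, separated from both others by more than the scatter. The two measured steps both alter this aryl group: a number 35.2 percentage points lower from compound 1 to compound 2 (beyond the scatter), and a number 24.1 percentage points lower from compound 1 to compound 3 (beyond the scatter).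

Compound 4 `COc1cc2c(cc1OC)C(CC(=O)Nc1cccnc1)CC2` differs from compound 2 by one change, (pyridin-3-yl in place of 2-methylphenyl on an amide-type nitrogen). Both measured steps show that the aryl group on the amide nitrogen moves the number in this assay by far more than the scatter, and that the 2-methylphenyl of compound 2 sits at the bottom of the series. Compound 4 is therefore expected to lie above compound 2, by a step of about a number 16.1 percentage points higher from compound 2 to compound 4 (beyond the scatter), giving an estimated value of 42% with a range from 22% to 62%.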

Compound 4, a percentage reported as inhibition, in the whole organism at one dose (the size of the read-out at that dose, not a potency): 35.2%
Estimate against measurement, compound 4: 6.8 percentage points above, and the stated range covers the measured number.
By their numbers in this assay, from the lowest: compounds 2, 4 and 3 (each within the scatter of the next, the first and the last beyond it); then compound 1.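

In this assay the change to pyridin-3-yl gives a number 9.3 percentage points higher from compound 2 to compound 4 (within the scatter), so this exchange, which brings in a ring nitrogen and replaces the carbon-only ring of 2-methylphenyl, does not separate the two compounds. The same group set against the 4-chlorophenyl gives a number 25.9 percentage points lower from compound 1 to compound 4 (beyond the scatter), which shows that a third aryl group on the amide nitrogen also stays well short of compound 1. Nothing measured here on these groups accounts for this result.

The compounds shown leave open how a 4-bromophenyl, a 4-methoxyphenyl or a cyclohexyl group on the amide nitrogen would read, and whether a carboxylic acid or an amine on the aryl ring would keep the level of compound 1. On these data alone, what a longer chain between the shared core and the amide would do also remains open.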